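The source may report more compounds than this note shows. Statements on the series, on what has been measured and on what is new or still open speak of the compounds shown alone.

Working notes on the series. In a functional assay on WI-38 VA13 cells (Homo sapiens) for cytotoxicity (on this read-out higher numbers stand for an effect only at larger amounts of compound and lower numbers for an effect already at smaller amounts), the measured compounds share one core and differ only in the group on one carbonyl carbon. Compound 1 `O=C(Nc1ccc2nc(NC(=O)C3CCCCC3)sc2c1)c1ccc(Br)cc1` gives > 4 ug/mL, which is a limit of the assay and not a number (the limit of > 4 ug/mL in this assay, at which 1 of the 3 values shown sits). Compound 2 `O=C(Nc1ccc2nc(NC(=O)C3CCCCC3)sc2c1)c1c(Cl)cccc1Cl` gives 0.015 ug/mL, and compound 3 `Cc1nc(C)c(C(=O)Nc2ccc3nc(NC(=O)C4CCCCC4)sc3c2)s1` gives 0.39 ug/mL. Compound 2 holds the lowest of the two numbers; the nearest is compound 3, with a 26-fold higher number from compound 2 to compound 3 (1.41 log units; beyond the scatter). The other steps are an at least 260-fold lower number from compound 1 to compound 2 (2.42 log units; beyond the scatter) and an at least 10-fold lower number from compound 1 to compound 3 (1.01 log units; beyond the scatter).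

Compound 4 `COC(=O)Nc1nc2ccc(NC(=O)c3c(Cl)cccc3Cl)cc2s1` keeps the 2,6-dichlorophenyl of compound 2 and is altered on the other carbonyl carbon: methoxy in place of cyclohexyl on a carbonyl carbon. None of the three measured steps touches this position; all three change the group on the other carbonyl carbon. For the measured compounds named here, no measured step therefore bears on this change, and no direction can be read from the numbers so far; the expectation is a number close to that already seen, with a wide range, and a 2.0-fold higher number from compound 2 to compound 4 (0.30 log units; within the scatter) is the step expected. Compound 4 is estimated at 0.03 ug/mL, between 0.005 ug/mL and 0.3 ug/mL.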

Compound 4, half-maximal effective concentration: 0.0095 ug/mL
For compound 4 the middle estimate is 3.2-fold (0.50 log units) above the measured one, and the stated range covers the measured number.
By their numbers in this assay, from the lowest: compounds 4 and 2 (each within the scatter of the next); then compound 3. At a limit, above all of these: compound 1.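

The step at this position reads a 1.6-fold lower number from compound 2 to compound 4 (0.20 log units; within the scatter), so with the 2,6-dichlorophenyl group held fixed, this assay does not separate methoxy from cyclohexyl on this carbonyl carbon. The six-membered carbon ring of compound 2 is therefore not needed for a number of this size, and the steps at the other carbonyl carbon, all beyond the scatter, contrast with this single step within it. No measurement shown gives a reason for this outcome.

From the compounds shown here alone, whether a free amine, a carboxylic acid or a longer chain on this carbonyl carbon would also stay within the scatter remains open. Also open, going by these compounds, is whether methoxy matches cyclohexyl when the other carbonyl carbon carries 4-bromophenyl or 2,4-dimethyl-1,3-thiazol-5-yl, since this position rests on one pair.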